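The compounds below may be only part of what the source reports. "The series", "measured", "known", "first", "only" and "open" are said of these compounds alone.

Measured compounds:
- compound 1, `CC(C)c1onc(-c2c(Cl)cccc2Cl)c1COc1ccc(NC(=O)c2ccc(C(=O)O)cc2)c(C(F)(F)F)n1`, 21%
- compound 2, `CC(C)c1onc(-c2c(Cl)cccc2Cl)c1COc1ccc(N(C)C(=O)c2cccc(C(=O)O)c2)c(C(F)(F)F)n1`, 35%

In a functional assay on HEK293 cells for agonist activity at Bile acid receptor (Homo sapiens) (a higher number here means a larger maximal response, a lower number a smaller maximal response), compound 1 gives 21% and compound 2 gives 35%. Compound 2 thus has the higher of the two numbers, and its gap to compound 1 lies beyond the scatter of this assay.

Compound 3, `CC(C)c1onc(-c2c(Cl)cccc2Cl)c1COc1ccc(N(C)Cc2ccc(OCC(=O)O)cc2)c(C(F)(F)F)n1`, has not been measured in this assay. It differs from compound 2 in one place: 4-(carboxymethoxy)benzyl in place of (3-carboxyphenyl)carbonyl on a nitrogen on an aromatic ring. The carbonyl that joins the aromatic ring to the nitrogen in compound 2 is gone, and the acid now sits on a carboxymethoxy chain. No step of this kind has been measured among the compounds shown, so the direction is uncertain. Compound 3 is expected to stay close to compound 2, with a step of a number 5 percentage points lower from compound 2 to compound 3 (within the scatter) that is estimated to lie within or only slightly beyond the scatter. Compound 3 is therefore estimated at 30%, in a range from 10% to 60%.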

Compound 3, largest response reached (reported as efficacy), in percent of the reference or control that the assay uses: 69%
For compound 3 the middle estimate is 39 percentage points below the measured one; the measured number lies above the stated range.
By their numbers in this assay, from the lowest: compound 1; then compound 2; then compound 3.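

In this assay the group on the nitrogen on an aromatic ring proves to have a strong bearing on the maximal response: putting 4-(carboxymethoxy)benzyl in place of (3-carboxyphenyl)carbonyl gives a number 34 percentage points higher from compound 2 to compound 3 (beyond the scatter) in a single change. Compound 3 has no carbonyl joining the aromatic ring to that nitrogen and still gives 69%, so this carbonyl is not required for a response of this size. Nothing in the data shown explains the step.

The change removes the carbonyl and moves the acid onto a carboxymethoxy chain at once, so the compounds shown do not separate these two parts of the step. A carboxybenzyl group, with the carboxylic acid directly on the ring, or a longer chain carrying the acid, would leave the open question of which part drives the rise.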